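The source may report more compounds than this note shows. Statements on the series, on what has been measured and on what is new or still open speak of the compounds shown alone.

In an ADME assay on HEK293 cells (Homo sapiens) for cytotoxicity, read by CellTiter-Glo and resazurin assay, with a stated time of 72 h (a lower number here means that less compound is needed, a higher number that more compound is needed for the effect), three compounds have been tested so far, and none of them gave a number. Compound 1, `CC(C)N(Cc1cccc(OCCCCCC(=O)O)c1)C(=O)c1ccccc1`, reaches only the limit of the assay, > 26000 nM. Compound 2, `CC(C)N(Cc1cccc(OCCCCCC(=O)O)c1)C(=O)c1ccc(-c2cccc(O)c2)cc1`, also stops at that limit, > 26000 nM. Compound 3, `CCOC(=O)CCCCCOc1cccc(CN(C(=O)c2ccccc2)C(C)C)c1`, stands at the limit as well, > 26000 nM. So compound 3 sits exactly where the other two sit, at the limit of > 26000 nM in this assay, at which 3 of the 3 values shown sit, and nothing finer can be said about its place.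

Compound 4, `CCOC(=O)CCCCCOc1cccc(CN(C(=O)c2ccc(-c3cccc(OC)c3)cc2)C(C)C)c1`, differs from compound 3 by 3-methoxyphenyl in place of hydrogen on an aromatic carbon. The closest measured precedent is a step that the two limits leave unreadable from compound 1 to compound 2, which adds a closely related group, 3-hydroxyphenyl in place of hydrogen on an aromatic carbon, and the other measured step, a step that the two limits leave unreadable from compound 1 to compound 3, concerns ethyl in place of hydrogen on an oxygen next to a carbonyl group. Both steps are hidden by the limit, so neither gives a size or a direction. With no readable step to lean on, compound 4 is expected to give a result near the limit, with an expected step of a number no higher from compound 3 to compound 4 (the limit leaves the size open). The estimate for compound 4 is 26000 nM, within 10000 nM to 60000 nM, and most likely the assay will again report only a limit.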

Compound 4, half-maximal effective concentration: > 21000 nM
Compound 4 ended at the assay's limit (the forecaster's own chance of this, stated with the estimate: 70%); the middle value does not contradict the limit.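

In this assay compound 4 gives only a limit (> 21000 nM), not a number. For the compounds shown here, compound 3 also gives only a limit (> 26000 nM), so no step from compound 3 to compound 4 can be read. The compounds shown leave open at what concentration, if any, these compounds reach the half-maximal effect, and whether adding 3-methoxyphenyl changes it.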